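A few compounds are considered here, and "the series" means these few. Any claim that something is new, unique, unknown or untested is made for them only; others in the source may bear on it.

Measured compounds and their values:

Compound 1, `CCCCCCCCCCNC(=O)[C@@H]1CSC(c2cc(OC)c(OC)c(OC)c2)N1`, 6700 nM
Compound 2, `CCCCCCCCCCCCNC(=O)[C@@H]1CSC(c2cc(OC)c(OC)c(OC)c2)N1`, 2400 nM
Compound 3, `CCCCCCCCCCCCCCNC(=O)[C@@H]1CSC(c2ccc(OC)c(OC)c2)N1`, 2800 nM

These three compounds were tested in an ADME assay on cells (Fibroblast, Homo sapiens) for antiproliferative activity, read by sulforhodamine B assay, with a stated time of 48 h; on this read-out lower numbers stand for stronger inhibition and higher numbers for weaker inhibition. Compound 1 and compound 2 share one core and differ only in the length of the chain on the amide nitrogen: the change ethyl in place of hydrogen on a saturated chain carbon, ten or more bonds along the chain from an amide-type nitrogen separates them, and the step was a 2.8-fold lower number from compound 1 to compound 2 (0.45 log units; beyond the scatter). Compound 3 carries a different core, and the difference between the two cores is not broken down here. In this assay compound 3 gives 2800 nM, a number close to that of compound 2, within the usual scatter.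

Compound 4, `CCCCCCCCCCCCCCCCNC(=O)[C@@H]1CSC(c2ccc(OC)c(OC)c2)N1`, has not yet been measured. It stands to compound 3 as compound 2 stands to compound 1: the change is ethyl in place of hydrogen on a saturated chain carbon, ten or more bonds along the chain from an amide-type nitrogen, the same change that was already seen, at a place described in the same words. For the measured compounds named here, because the earlier step was a 2.8-fold lower number from compound 1 to compound 2 (0.45 log units; beyond the scatter), a lowering of the number is expected again, though only one earlier example exists and nothing shows that the change must act alike on the core of compound 3. The step from compound 3 to compound 4 is expected to be a 1.8-fold lower number from compound 3 to compound 4 (0.24 log units; within the scatter), somewhat smaller than the earlier one, since a single instance is a thin basis. For compound 4 in this assay the estimate is 1600 nM, with a range from 700 nM to 4000 nM.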

Compound 4, half-maximal inhibitory concentration: 2100 nM
For compound 4 the middle estimate is 1.3-fold (0.12 log units) below the measured one; measured number inside the range.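

In this assay, the same lengthening of the chain on the amide nitrogen, ethyl in place of hydrogen on a saturated chain carbon, gives a 1.3-fold lower number from compound 3 to compound 4 (0.12 log units; within the scatter). Set beside the earlier step on the core of compound 1, this result gives no sign that the change behaves differently on the two cores, since the gap between the two steps is no larger than repeated measurements could produce: the same change on two cores in this assay, a 2.8-fold lower number (0.45 log units; beyond the scatter) from compound 1 to compound 2 and a 1.3-fold lower number (0.12 log units; within the scatter) from compound 3 to compound 4, 2.1-fold (0.32 log units) apart, within the scatter of two such steps. This supports carrying the change from one core to the other only in a limited way: the new step taken alone lies within the scatter, so it does not establish a real effect of the longer chain on the core of compound 3, and two pairs of compounds cannot show that the effect is equal on both cores or extends to other cores.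

No two compounds shown carry the same chain on the two cores, so the effect of the core itself remains separate and open. Going by these compounds, it also remains open how the number would respond on either core to a longer chain than that of compound 4, or to a chain ending in an amine or a carboxylic acid.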